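The source may hold more compounds than are shown below. What is called first, only, known or untested is meant among the compounds shown, and "the series" means these compounds.

Measured so far:
compound 1 `CN1C(=O)C(CCNc2ccc(F)cc2)COC12C=CC(=O)C=C2` gives 11600 nM in an assay on isolated protein for inhibition of N-lysine methyltransferase SMYD2 (Homo sapiens), read by filter binding, with a stated time of 1 h; on this read-out higher numbers stand for weaker inhibition and lower numbers for stronger inhibition;
compound 2 `CN1C(=O)C(CCNc2ccc(C(=O)c3ccccc3)cc2)COC12C=CC(=O)C=C2` gives > 20000 nM in this assay, a limit of the assay rather than a number.

Compound 2 therefore stands at the weak end of what this assay can report, (the limit of > 20000 nM in this assay, at which 1 of the 2 values shown sits). Compound 3 `CN1C(=O)C(CCNc2ccc(-c3cccs3)cc2)COC12C=CC(=O)C=C2` differs from it by one change, (thiophen-2-yl in place of benzoyl on an aromatic carbon). Among the measured compounds shown here, the only measured step is an at least 1.7-fold higher number from compound 1 to compound 2 (0.23 log units; that floor lies within the scatter), which lies within the scatter and involves a different group at the same place. Little can be carried over, so no clear step beyond the scatter is expected for a number no higher from compound 2 to compound 3 (the limit leaves the size open). Compound 3 is estimated at 20000 nM, between 8000 nM and 60000 nM.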

Compound 3, half-maximal inhibitory concentration: 2310 nM
Beside the measured number, compound 3's estimate is 8.7-fold (0.94 log units) above it; the measured number lies below the stated range.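

This position on the aromatic ring clearly responds to what sits there: in this assay, thiophen-2-yl gives stronger inhibition than fluoro, with a 5.0-fold lower number from compound 1 to compound 3 (0.70 log units; beyond the scatter). Thiophen-2-yl also outperforms benzoyl, with an at least 8.6-fold lower number from compound 2 to compound 3 (0.93 log units; beyond the scatter). That size is only a floor, because the value of compound 2 is a limit and not a number: the limit of > 20000 nM in this assay, at which 1 of the 3 values shown sits.

The compounds shown leave open whether the sulfur of the thiophene matters or any directly attached aromatic ring would do. Phenyl or furan-2-yl at this place would separate those two readings.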